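The source may report more compounds than this note shows. Statements on the series, on what has been measured and on what is new or still open speak of the compounds shown alone.

Measured so far in an ADME assay on MT4 cells (Homo sapiens) for cytotoxicity, read by MTT assay, with a stated time of 4 days; a higher number here means that more compound is tolerated, a lower number that less compound is tolerated:

- compound 1 `N#Cc1ccc(Nc2nc(Oc3ccc(Cl)cc3Cl)c3ccccc3n2)cc1`: compound 1 gives 32000 nM
- compound 2 `N#Cc1ccc(Nc2nc(Oc3c(Cl)cc(Cl)cc3Cl)c3ccccc3n2)cc1`: compound 2 gives 56000 nM

For the measured compounds named here, compound 2 holds the highest of the two numbers in this assay; its nearest neighbour is compound 1, and the single step recorded, a 1.8-fold higher number from compound 1 to compound 2 (0.24 log units; within the scatter), is within the scatter, so the two compounds cannot be separated on tolerance.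

Compound 3 `Cc1ccccc1Oc1nc(Nc2ccc(C#N)cc2)nc2ccccc12` is the next compound in the series. Its change against compound 2 is 2-methylphenyl in place of 2,4,6-trichlorophenyl on an oxygen on an aromatic ring. Going by the values given here, the only measured step concerns the same aryl ether group, but it touches one aromatic carbon only and produced no shift beyond the scatter; a wholesale exchange of the aryl group has no measured precedent here, so the step of a 1.8-fold higher number from compound 1 to compound 2 (0.24 log units; within the scatter) offers only weak guidance. With nothing in the measured pair pointing in either direction, the expectation for compound 3 is a number near that of compound 2, the expected step of a 1.4-fold lower number from compound 2 to compound 3 (0.15 log units; within the scatter) lying within the scatter. Compound 3 is therefore estimated in this assay at 40000 nM, with a likely range from 15000 nM to 100000 nM.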

Compound 3, half-maximal cytotoxic concentration: 355000 nM
Beside the measured number, compound 3's estimate is 8.9-fold (0.95 log units) below it; measured number above the stated range.
By their numbers in this assay, from the lowest: compounds 1 and 2 (each within the scatter of the next); then compound 3.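

In this assay the aryl group on the oxygen proves to be a place where the number can move beyond the scatter, since the exchange for 2-methylphenyl gives two clear steps (a 6.3-fold higher number from compound 2 to compound 3 (0.80 log units; beyond the scatter)) and (an 11-fold higher number from compound 1 to compound 3 (1.05 log units; beyond the scatter)). The earlier pair showed only that one chloro more on this aryl group leaves compound 1 and compound 2 inseparable, whereas replacing the whole chlorinated aryl group with 2-methylphenyl, which holds carbon only, sets compound 3 apart from both. No measured evidence at hand bears on what lies behind these steps.

The exchange removes every chlorine and adds a methyl in a single change, so the compounds shown cannot say whether the chlorine atoms leaving or the methyl entering carries the step; a plain phenyl or a 2-chlorophenyl on the same oxygen would separate the two. Also open, as far as these compounds go, is whether the higher number depends on an aromatic ring at this place at all, which a cyclohexyl group on the oxygen, or an amine in place of the aryl ether, would address.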